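Ester swap: isopropyl to cyclopropylmethyl in a pyrimidinone series

The source may hold more compounds than are shown below. What is called first, only, known or untested is meant among the compounds shown, and "the series" means these compounds.

Three compounds share one core and differ in the ester group and one alkyl substituent. Compound 1 `CCCCc1nc(C(C)C)c(CC(=O)OC)c(=O)n1Cc1ccc(-c2ccccc2-c2noc(=O)[nH]2)cc1` carries a methyl ester; in an ADME assay on microsomes from liver (Mus musculus) for metabolic stability, with a stated time of 30 min (on this read-out lower numbers stand for a less stable compound and higher numbers for a more stable compound), compound 1 gives 9.4%. Compound 2 `CCCCc1nc(C(C)C)c(CC(=O)OCC(F)(F)F)c(=O)n1Cc1ccc(-c2ccccc2-c2noc(=O)[nH]2)cc1` carries a trifluoroethyl ester, and in this assay compound 2 gives "not determined" (no result reported). Compound 3 `CCCCc1nc(C)c(CC(=O)OC(C)C)c(=O)n1Cc1ccc(-c2ccccc2-c2noc(=O)[nH]2)cc1` carries an isopropyl ester; in this assay compound 3 gives 4%, the lowest of the two numbers, and the gap to compound 1 lies within the scatter, so the two cannot be ordered.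

Compound 4 `CCCCc1nc(C)c(CC(=O)OCC2CC2)c(=O)n1Cc1ccc(-c2ccccc2-c2noc(=O)[nH]2)cc1` differs from compound 3 in one place: cyclopropylmethyl in place of isopropyl on an oxygen next to a carbonyl group, with cyclopropylmethyl in place of isopropyl on an oxygen next to a carbonyl group. Within the data shown here, no measured pair shows what an ester change does here. Because compound 3 gives 4% and compound 1 gives 9.4%, both small numbers, the expected step of a number 2 percentage points higher from compound 3 to compound 4 (within the scatter) is small and within the scatter, in no clear direction. Compound 4 is therefore expected to give about 6%, with a range from 1% to 20%.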

Compound 4, percent of the compound remaining: 13%
For compound 4 the middle estimate is 7 percentage points below the measured one; low and high end bracket the measured number.
By their numbers in this assay, from the lowest: compounds 3, 1 and 4 (each within the scatter of the next).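

Among these compounds, this pair is the first in which the ester group alone changes while the rest of the molecule stays the same. In this assay, putting cyclopropylmethyl in place of isopropyl on an oxygen next to a carbonyl group gives a number 9 percentage points higher from compound 3 to compound 4 (within the scatter), so replacing a group with no ring by one with a three-membered ring leaves no difference that can be told from the scatter at this position. Nothing at hand explains the read-out of either compound.

As far as these compounds go, whether a longer chain such as n-butyl, or an ester bearing an amine or a carboxylic acid, would stand clear of the scatter remains open. Compounds 1 and 3 differ in two places, so the ester and the alkyl group on the shared core cannot yet be judged separately.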